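The compounds below may be only part of what the source reports. "The series", "measured", "known", "first", "only" and "open" are said of these compounds alone.

Of the compounds shown here, two of a shared sulfonamide series have been tested in an assay on VSM-A10 cells for antagonist activity at Endothelin-1 receptor (Rattus norvegicus); a higher number here means a weaker inhibitor, a lower number a stronger inhibitor. Compound 1 `CCOC(=O)C(C)Nc1cccc2c(S(=O)(=O)Nc3onc(C)c3C)cccc12` gives 400 nM, and compound 2 `Cc1onc(NS(=O)(=O)c2cccc3c(N(C)C)cccc23)c1C` gives 60 nM. Of these two numbers, compound 1 has the higher one, so it is the weaker inhibitor, and the gap to compound 2 lies beyond the usual scatter of this assay.

Compound 3 `Cc1noc(NS(=O)(=O)c2cccc3c(NC(C)C)cccc23)c1C` has not yet been measured. It differs from compound 1 by methyl in place of ethoxycarbonyl on a saturated chain carbon bound to a nitrogen on an aromatic ring and a saturated chain carbon. The result is a plain isopropylamino group on the core in place of the larger ester-bearing chain.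

A downward step a 4.0-fold lower number from compound 1 to compound 3 (0.60 log units; beyond the scatter) is expected here, because compound 2, which also carries only small alkyl groups on that nitrogen, gives 60 nM. Compound 3 is therefore estimated to give 100 nM in this assay, with a likely range from 30 nM to 350 nM.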

Compound 3, half-maximal inhibitory concentration: 20 nM
Beside the measured number, compound 3's estimate is 5.0-fold (0.70 log units) above it, and the stated range ends above it.
By their numbers in this assay, from the lowest: compound 3; then compound 2; then compound 1.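

In this assay the group on the saturated chain carbon strongly affects the result: replacing ethoxycarbonyl with methyl gives (a 20-fold lower number from compound 1 to compound 3 (1.30 log units; beyond the scatter)), a large change beyond the scatter. This shows that the position is sensitive to this change, and that the plain isopropylamino group gives a stronger inhibitor than the ester-bearing chain on the otherwise identical core. No supporting measurement is available to explain the size of this step.

This single step cannot separate the loss of the ester itself from the change to a smaller group. A carboxylic acid or an amide on that carbon, or a longer chain such as sec-butyl on the nitrogen, would be needed to tell these two readings apart, and the compounds shown leave this open.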